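A Methyl Next to the Ring Nitrogen

The compounds below may be only part of what the source reports. "The series", "measured", "known", "first", "only" and "open" are said of these compounds alone.

Compound 1 `N/C(=N\NC(=S)N1CCCCCC1)c1ccccn1` is the reference point of this small set. In a functional assay on MCF7 cells (Homo sapiens) for cytotoxicity, read by MTT assay, with a stated time of 72 h, tested at 100 uM (a higher number here means more inhibition of growth at the concentration tested, a lower number less inhibition of growth), compound 1 gives 84%, the highest of the two numbers available, with compound 2 the nearest neighbour. Compound 2 `Cc1ccnc(/C(N)=N/NC(=S)N2CCCCCC2)c1` carries a methyl in place of hydrogen on an aromatic carbon of the shared core, and in this assay compound 2 gives 65.4%. The step of a number 18.6 percentage points lower from compound 1 to compound 2 (beyond the scatter) shows that this single methyl costs a modest but real amount of growth inhibition.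

Compound 3 `Cc1cccc(/C(N)=N/NC(=S)N2CCCCCC2)n1` has not been measured in this assay. It differs from compound 1 by methyl in place of hydrogen on an aromatic carbon, the methyl now sitting next to the ring nitrogen and meta to a large group. Among the compounds with values here, the only step that bears on this change is the one from compound 1 to compound 2, the same kind of substitution at a different aromatic carbon. On that basis a downward step of comparable size is expected, though the position differs and the second methyl position could behave otherwise. Compound 3 is therefore estimated at 68%, within a range from 50% to 85%, which corresponds to an expected step of a number 16 percentage points lower from compound 1 to compound 3 (beyond the scatter).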

Compound 3, percent growth inhibition at one concentration: 70.2%
For compound 3 the middle estimate is 2.2 percentage points below the measured one; low and high end bracket the measured number.
By their numbers in this assay, from the lowest: compounds 2 and 3 (each within the scatter of the next); then compound 1.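

In this assay the methyl next to the ring nitrogen also lowers growth inhibition, with a number 13.8 percentage points lower from compound 1 to compound 3 (beyond the scatter) as the step, so the loss that came with the methyl of compound 2 is not confined to that one aromatic carbon. Compound 2 at 65.4% and compound 3 at 70.2% lie within the usual scatter of each other, so this read-out does not separate the two methyl placements, although each stands beyond the scatter from compound 1. Nothing available explains the loss at either carbon.

The compounds shown leave open how a methyl would behave on the remaining aromatic carbons of the shared core, and whether the loss follows from methyl specifically or would also appear with another group at the place next to the ring nitrogen, such as an amine, a methoxy group or a longer chain like ethyl. They also leave open whether the same steps would appear at other concentrations, since each number here comes from a single tested concentration.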